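The source may hold more compounds than are shown below. What is called first, only, known or untested is meant among the compounds shown, and "the series" means these compounds.

Working notes on the series at a functional assay on HEK293 cells for agonist activity at G-protein coupled receptor 39 (Homo sapiens), read by scintillation proximity assay and inositol phosphate accumulation, with a stated time of 75 min; on this read-out higher numbers stand for an effect only at larger amounts of compound and lower numbers for an effect already at smaller amounts.

Compound 1, `Cc1nn(-c2ncnc3nc[nH]c23)c2c1C(OCCc1ccccc1)CC(=O)N2`, gives 40 nM in this assay. Compound 2, `CCC(C(=O)NC1CC(=O)Nc2c1c(C)nn2-c1ncnc2nc[nH]c12)c1ccccc1`, gives 79 nM in this assay. Compound 1 has the lowest of the two numbers shown, but the gap to compound 2 lies within the scatter, so no order between the two is claimed.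

Compound 3, `Cc1nn(-c2ncnc3nc[nH]c23)c2c1C(OCc1ccc(Cl)cc1Cl)CC(=O)N2`, has not yet been measured. It differs from compound 1 in one place: 2,4-dichlorophenyl in place of benzyl on a saturated chain carbon bound to an oxygen on a saturated carbon. The ether oxygen on the saturated chain of the shared core is kept; only what hangs from the saturated chain carbon beyond it changes.

Among the measured compounds shown here, no pair of measured compounds differing in one place is available, so the size of this kind of step cannot be read from the series itself. On the two values shown, the step from compound 1 to compound 3 is expected to be small, in either direction, and most likely not beyond the scatter, as a 1.5-fold higher number from compound 1 to compound 3 (0.18 log units; within the scatter). For compound 3 the value in this assay is estimated at 60 nM, with a range from 15 nM to 250 nM.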

Compound 3, half-maximal effective concentration: 243 nM
Beside the measured number, compound 3's estimate is 4.1-fold (0.61 log units) below it; low and high end bracket the measured number.
By their numbers in this assay, from the lowest: compounds 1 and 2 (each within the scatter of the next); then compound 3.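

In this assay, among the compounds shown here, this position proves not to be indifferent to what hangs beyond the ether oxygen: 2,4-dichlorophenyl in place of benzyl on a saturated chain carbon bound to an oxygen on a saturated carbon gives a 6.1-fold higher number from compound 1 to compound 3 (0.78 log units; beyond the scatter), the only step that can be read so far. The ether oxygen and the shared core are kept, but cut one bond further out the same difference reads phenethyl to 2,4-dichlorobenzyl, so the chain and the chlorine atoms on the ring change within a single step. Nothing at hand gives a reason for the size of this step.

The compounds shown leave open whether the higher number goes with the two chlorine atoms, with the change in the chain, or with both, and a plain benzyl or a 2,4-dichlorophenethyl group on the same oxygen would separate these readings. Also open, as far as these compounds go, is how a single chlorine atom on the ring, or an amine in place of the ether oxygen, would read in this assay.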